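Removing the chloro from compound 2

The compounds below may be only part of what the source reports. "The series", "measured", "known", "first", "only" and "open" are said of these compounds alone.

Measured in a functional assay on Jurkat cells (Homo sapiens) for antiproliferative activity, read by MTT assay, with a stated time of 72 h; on this read-out lower numbers stand for stronger inhibition and higher numbers for weaker inhibition:
Compound 1 `COc1ccc(-c2ncnn2-c2cc(OC)c(OC)c(OC)c2)cc1`: 50 nM
Compound 2 `CCOc1ccc(-c2ncnn2-c2cc(OC)c(OC)c(OC)c2)cc1Cl`: 3 nM

Compound 2 has the lower of these two numbers, and its gap to compound 1 lies beyond the usual scatter of repeated measurements. Compound 3 `CCOc1ccc(-c2ncnn2-c2cc(OC)c(OC)c(OC)c2)cc1` is compound 2 with a single change, hydrogen in place of chloro on an aromatic carbon, ortho to an ethoxy group. Going by the values given here, no measured pair shows this change alone, so its size in this assay must be judged indirectly. Compound 1 also carries no chloro, and it gives 50 nM, which suggests that the number may rise. The expected change is a 6.7-fold higher number from compound 2 to compound 3 (0.82 log units; beyond the scatter), a weakening beyond the scatter. For compound 3 the estimated value is 20 nM, with an expected range of 6 nM to 70 nM.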

Compound 3, half-maximal inhibitory concentration: 5 nM
Compound 3: the middle estimate sits 4.0-fold (0.60 log units) above what was measured, outside the stated range (below it).
By their numbers in this assay, from the lowest: compounds 2 and 3 (each within the scatter of the next); then compound 1.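

In this assay, hydrogen in place of chloro on an aromatic carbon, ortho to an ethoxy group, gives a 1.7-fold higher number from compound 2 to compound 3 (0.22 log units; within the scatter), so compound 2 and compound 3 cannot be told apart on this read-out. Going by these compounds alone, the single change that does exceed the scatter lies in the alkoxy chain: methyl in place of hydrogen on a saturated chain carbon bound to an oxygen on an aromatic ring, which turns methoxy into ethoxy, gives a 10-fold lower number from compound 1 to compound 3 (1.00 log units; beyond the scatter), a modest step. No measurement shown here accounts for either result.

The compounds shown leave open whether a fluoro, a methyl or an amine on that aromatic carbon would give a number different from those of hydrogen and chloro. They also leave open whether a longer chain, such as propoxy, in place of the ethoxy group would extend the step seen from methoxy to ethoxy.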